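The compounds below may be only part of what the source reports. "The series", "measured", "known", "first", "only" and "open" are said of these compounds alone.

Notes on the series

Compound 1 `O=C(Nc1ccccc1C(F)(F)F)C1CCc2ccccc2N1` carries the unsubstituted ring nitrogen of the shared core and a single trifluoromethyl on the anilide ring. In a functional assay on NUGC-3 cells (Homo sapiens) for cytotoxicity, read by sulforhodamine B assay, with a stated time of 72 h (a lower number here means a stronger inhibitor of growth, a higher number a weaker inhibitor of growth), compound 1 gives 39300 nM. Compound 2 `O=C(Nc1ccccc1C(F)(F)F)C1CCc2ccccc2N1C(=O)c1ccccc1` is the benzoylated counterpart, differing from compound 1 by benzoyl in place of hydrogen on a nitrogen on an aromatic ring in a ring. In this assay compound 2 gives 8120 nM, so the step of a 4.8-fold lower number from compound 1 to compound 2 (0.68 log units; beyond the scatter).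

Compound 3 `O=C(Nc1cc(C(F)(F)F)cc(C(F)(F)F)c1)C1CCc2ccccc2N1` keeps the free ring nitrogen but carries two trifluoromethyl groups on the anilide ring. In this assay compound 3 gives 8760 nM. The difference between the core of compound 3 and the core of compound 1 is not broken down here. The values of compound 3 and compound 2 lie within the scatter of each other; compound 3 against compound 1 shows the lower number.

Compound 4 `O=C(Nc1cc(C(F)(F)F)cc(C(F)(F)F)c1)C1CCc2ccccc2N1C(=O)c1ccccc1` has not yet been measured. It differs from compound 3 by benzoyl in place of hydrogen on a nitrogen on an aromatic ring in a ring, the same change as that from compound 1 to compound 2, at the same place. The expectation for compound 4 rests on one prior example, the step of a 4.8-fold lower number from compound 1 to compound 2 (0.68 log units; beyond the scatter); with one case only, the step is expected to go the same way but its size is uncertain. The step is estimated as a 3.5-fold lower number from compound 3 to compound 4 (0.54 log units; beyond the scatter). Compound 4 is therefore expected to give about 2500 nM in this assay, with a likely range from 900 nM to 7000 nM.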

Compound 4, concentration for 50% growth inhibition: 1680 nM
Estimate against measurement, compound 4: 1.5-fold (0.17 log units) above; low and high end bracket the measured number.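

On the core of compound 3, benzoyl in place of hydrogen on a nitrogen on an aromatic ring in a ring gives a 5.2-fold lower number from compound 3 to compound 4 (0.72 log units; beyond the scatter) in this assay. In these two pairs, the change therefore carries from one anilide ring to the other with its direction and its size kept: the same change on two cores in this assay, a 4.8-fold lower number (0.68 log units; beyond the scatter) from compound 1 to compound 2 and a 5.2-fold lower number (0.72 log units; beyond the scatter) from compound 3 to compound 4, 1.1-fold (0.03 log units) apart, within the scatter of two such steps

Among these compounds, this agreement rests on only two pairs, both with trifluoromethyl on the anilide ring and both read in a single cell assay, and it does not show that the step would keep its size on an anilide ring of another kind, in another cell line, or for any reason that could be named from these numbers.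

Still open, going by these compounds, is whether the step belongs to benzoyl itself or would also appear with a smaller acyl group such as acetyl, a longer acyl chain, or a benzoyl ring carrying an amine or a carboxylic acid. Equally open is whether the step holds on anilide rings with no trifluoromethyl, for example rings carrying a nitrile or a methoxy group, since all four compounds shown have trifluoromethyl there.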